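This account rests on a few compounds, and the source may have more. Where it says the series, first, only, none or still open, it means among the compounds named here.

Measured so far:
compound 1, `CC(=O)c1ccc(Nc2ccnc(SCC(=O)c3ccc(Br)cc3)n2)cc1`, 38%
compound 2, `CCOC(=O)c1ccc(Nc2ccnc(SCC(=O)c3ccc([N+](=O)[O-])cc3)n2)cc1`, 41%

In a functional assay on UO-31 cells (Homo sapiens) for inhibition, read by sulforhodamine B assay, with a stated time of 48 h, tested at 10 uM (on this read-out higher numbers stand for more inhibition of growth at the one concentration tested and lower numbers for less inhibition of growth), compound 1 gives 38%. Compound 2 gives 41%, a number that lies within the usual scatter of the value of compound 1, so the two compounds cannot be told apart on this read-out. Compound 3 `CC(=O)c1ccc(Nc2ccnc(SCC(=O)c3ccc(-c4ccccc4)cc3)n2)cc1` has not been measured; it differs from compound 1 in one place: phenyl in place of bromo on an aromatic carbon. Among the measured compounds shown here, no pair of measured compounds shows what such a change does, and compound 2 differs from compound 1 in more than one place, so its value tells only how close the measured numbers are. The step of a number 2 percentage points higher from compound 1 to compound 3 (within the scatter) is expected to stay within the scatter, with no clear direction. Compound 3 is therefore expected to give 40%, with a range from 22% to 58%.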

Compound 3, percent growth inhibition at one concentration: 27%
Beside the measured number, compound 3's estimate is 13 percentage points above it; measured number inside the range.
By their numbers in this assay, from the lowest: compound 3; then compounds 1 and 2 (each within the scatter of the next).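

In this assay, among the compounds shown here, putting phenyl in place of bromo on this aromatic carbon, para to a large group, gives the first change that can be read in one place: a number 11 percentage points lower from compound 1 to compound 3 (beyond the scatter). This position is therefore not indifferent to what it carries, and in this one pair, the single bromine atom gives way to a six-carbon aromatic ring with less inhibition of growth as the result. Nothing available explains this step.

A single pair cannot show whether the number follows the size of the group or something else, and a methyl group, an amine or a carboxylic acid at this place would help to separate those readings. Going by these compounds, it also remains open whether the same change would give a similar step with the other groups of compound 2 in place.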